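Extending an Alkyl Chain on a Shared Core

The compounds below may be only part of what the source reports. "The series", "measured", "known", "first", "only" and "open" are said of these compounds alone.

Compound 1, `COc1ccc(-c2cc(Cl)cc(C(=O)Nc3nn[nH]n3)n2)cc1`: 43%
Compound 2, `Cc1ccc(-c2cc(Cl)cc(C(=O)Nc3nn[nH]n3)n2)cc1`: 86%
Compound 3, `CCCc1ccc(-c2cc(Cl)cc(C(=O)Nc3nn[nH]n3)n2)cc1`: 78%

Three compounds share one core and differ only in the group on the outer aromatic ring. They were tested in a functional assay on the whole organism with Rattus norvegicus as the target, at a dose of 1 mg/kg by the oral route; on this read-out lower numbers stand for a weaker effect and higher numbers for a stronger effect at the one dose given. Compound 3 stands second highest of the three numbers. Its nearest neighbour is compound 2, with a number 8 percentage points lower from compound 2 to compound 3 (within the scatter), a gap within the scatter; its furthest is compound 1, with a number 35 percentage points higher from compound 1 to compound 3 (beyond the scatter), a gap beyond it.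

Compound 4, `CCCCc1ccc(-c2cc(Cl)cc(C(=O)Nc3nn[nH]n3)n2)cc1`, has not yet been measured. (methyl in place of hydrogen on a saturated chain carbon, three bonds along the chain from an aromatic carbon). Read one bond further out, the same change turns propyl into butyl.

Going by the values given here, only one measured step bears on lengthening this chain: a number 8 percentage points lower from compound 2 to compound 3 (within the scatter), which stayed within the scatter. The two large steps, a number 43 percentage points higher from compound 1 to compound 2 (beyond the scatter) and a number 35 percentage points higher from compound 1 to compound 3 (beyond the scatter), replace methoxy with a chain rather than lengthen a chain, so they say little about compound 4. With a single guiding step that showed no change, the expected step is a number 3 percentage points lower from compound 3 to compound 4 (within the scatter), within the scatter and with no clear direction. Compound 4 is therefore expected to give about 75%, with a range from 55% to 92%.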

Compound 4, a percentage reported as inhibition, in the whole organism at one dose (the size of the read-out at that dose, not a potency): 0%
Compound 4: the middle estimate sits 75 percentage points above what was measured; the whole stated range lies above it.
By their numbers in this assay, from the lowest: compound 4; then compound 1; then compounds 3 and 2 (each within the scatter of the next).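

The result shows that lengthening the chain at this place does not have a steady effect. In this assay, the earlier lengthening from methyl to propyl gave a number 8 percentage points lower from compound 2 to compound 3 (within the scatter) and so showed no clear change, yet one further methyl on the end of the chain, turning propyl into butyl, gives a number 78 percentage points lower from compound 3 to compound 4 (beyond the scatter) and removes the whole effect seen at this dose. The butyl compound also falls well short of the other two outer groups, with a number 86 percentage points lower from compound 2 to compound 4 (beyond the scatter) and a number 43 percentage points lower from compound 1 to compound 4 (beyond the scatter) and thus lies even under the methoxy compound, the lowest of the earlier three.

The compounds shown leave open whether the loss is specific to butyl or would persist with a longer chain such as pentyl, and whether a branched group such as isopropyl or tert-butyl, or a ring such as cyclopropyl, would keep the effect seen with propyl. They also offer no measurement that explains why the effect disappears at butyl, so the sharp drop stands here as an observation only.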